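A few compounds are considered here, and "the series" means these few. Any claim that something is new, unique, unknown or untested is made for them only; others in the source may bear on it.

Measured compounds:
- Compound 1, `CC(C)Cc1cc2oc(=O)n(CCC(=O)O)c2cc1Cl`, in an assay on HEK293 cells for inhibition of kynurenine 3-monooxygenase (Homo sapiens), read by LC-MS, with a stated time of 20 h (a lower number here means a stronger inhibitor, a higher number a weaker inhibitor), compound 1 gives 794 nM.
- Compound 2, `Cc1ccc([C@@H](C)Oc2cc3onc(CCC(=O)O)c3cc2Cl)nn1`, in this assay compound 2 gives 3.16 nM.

Within the data shown here, these two compounds share a propanoic acid chain on a two-ring core that carries a chlorine, but they differ in several places at once, so no single step between them can be read; the two numbers simply show that compound 2 sits far lower than compound 1, the gap lying well beyond the usual scatter. Compound 2 therefore stands as the lowest of the two numbers.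

Compound 3, `C[C@@H](Oc1cc2onc(CCC(=O)O)c2cc1Cl)c1ccc(Cl)cn1`, has not yet been measured in this assay. It differs from compound 2 in one place: 5-chloropyridin-2-yl in place of 6-methylpyridazin-3-yl on a saturated chain carbon bound to an oxygen on an aromatic ring and a saturated chain carbon. One six-membered aromatic group gives way to another of the same size, and the rest of the molecule stays as it is. Among the measured compounds shown here, with no comparable step between measured compounds to lean on, the expectation is for a small step, or none beyond the scatter, in this assay. For compound 3 the estimated value is 3.5 nM, with a range from 1 nM to 12 nM, which means an expected step of a 1.1-fold higher number from compound 2 to compound 3 (0.04 log units; within the scatter).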

Compound 3, half-maximal inhibitory concentration in the kynurenine 3-monooxygenase assay: 3.98 nM
Beside the measured number, compound 3's estimate is 1.1-fold (0.06 log units) below it, within the range that was stated.
By their numbers in the kynurenine 3-monooxygenase assay, from the lowest: compounds 2 and 3 (each within the scatter of the next); then compound 1.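

Among these compounds, in the kynurenine 3-monooxygenase assay, putting 5-chloropyridin-2-yl in place of 6-methylpyridazin-3-yl on this saturated chain carbon gives a 1.3-fold higher number from compound 2 to compound 3 (0.10 log units; within the scatter), so this pair, unlike compounds 1 and 2, whose many differences leave no single step to read, shows that one six-membered aromatic ring can replace the other here with no shift beyond the scatter. In a physicochemical assay for solubility, with a stated time of 24 h (a lower number here means a less soluble compound, a higher number a more soluble compound), the same change gives an at least 2.6-fold higher number from compound 2 to compound 3 (0.43 log units; beyond the scatter), so the pair that cannot be told apart in the kynurenine 3-monooxygenase assay does separate in the physicochemical assay. In the physicochemical assay compound 2 gives 230 ug/mL. In the physicochemical assay compound 3 gives > 620 ug/mL, which is a limit of the assay and not a number: the limit of > 620 ug/mL in the physicochemical assay, at which 1 of the 2 values shown sits.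

The change swaps a ring nitrogen and a methyl for a chlorine in one move, so the compounds shown cannot say which part lies behind the step in the physicochemical assay, and a 5-methylpyridin-2-yl group would separate the two. Going by these compounds, it also remains open how far this position tolerates other groups in the kynurenine 3-monooxygenase assay, such as a plain phenyl ring or a saturated cyclohexyl ring.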